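The compounds below may be only part of what the source reports. "The series", "measured", "known", "first", "only" and "open" are said of these compounds alone.

Measured so far:
compound 1 `CSc1nc(NCc2ccccc2)c2c(n1)C(=O)C(c1ccccc1)=[N+]2[O-]` gives 59000 nM
compound 2 `Nc1nc(NCc2ccccc2)nc2c1[N+]([O-])=C(c1ccccc1)C2=O` gives 3700 nM

In a functional assay on A2780 cells (Homo sapiens) for antiproliferative activity, read by sulforhodamine B assay, with a stated time of 48 h (a lower number here means a stronger inhibitor of growth, a higher number a weaker inhibitor of growth), compound 2 gives 3700 nM, the lowest of the two numbers available. Among the measured compounds shown here, its only neighbour is compound 1, and compound 1 gives 59000 nM, a gap that lies beyond the usual scatter of repeated measurements, so compound 2 is the stronger growth inhibitor of the two.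

Compound 3 `Nc1nc(NCCN2CCCC2)nc2c1[N+]([O-])=C(c1ccccc1)C2=O` keeps the core of compound 2 and alters only the group attached through the chain to the ring nitrogen: (pyrrolidin-1-yl)methyl in place of phenyl on a saturated chain carbon bound to a nitrogen on an aromatic ring. For the measured compounds named here, no measured pair of compounds shows this change, so its effect has no precedent here. The expected step from compound 2 to compound 3 is a 1.5-fold higher number from compound 2 to compound 3 (0.17 log units; within the scatter), a slight weakening that need not exceed the scatter. Compound 3 is therefore estimated at 5500 nM, with a range from 1500 nM to 20000 nM.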

Compound 3, concentration for 50% growth inhibition: 2600 nM
The estimate for compound 3 lay 2.1-fold (0.33 log units) above the measured number, within the range that was stated.
By their numbers in this assay, from the lowest: compounds 3 and 2 (each within the scatter of the next); then compound 1.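

Placing (pyrrolidin-1-yl)methyl in place of phenyl on a saturated chain carbon bound to a nitrogen on an aromatic ring gives, in this assay, a 1.4-fold lower number from compound 2 to compound 3 (0.15 log units; within the scatter). For this pair, then, growth inhibition at this position does not depend on the six-membered aromatic ring of carbon only: a five-membered non-aromatic ring with a nitrogen in it serves within the scatter. Nothing measured here explains this result.

Still open, as far as these compounds go, is how far this tolerance extends at the same position, for example to a piperidine or morpholine ring, an open-chain dimethylamino group, or a longer chain between the ring and the amino nitrogen. Also open, from the compounds shown here alone, is whether the same exchange would give a similar step on a core carrying different groups elsewhere.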